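A few compounds are considered here, and "the series" means these few. Any claim that something is new, unique, unknown or untested is made for them only; others in the source may bear on it.

Compound 1 `Cc1ccc(NC2=NC(=O)/C(=C/c3cccc(O)c3)S2)c(Cl)c1` and compound 2 `CCOC(=O)C1=C(Nc2ccc(Cl)cc2)S/C(=C\c2cccc(O)c2)C1=O` were both tested in an assay on isolated protein for activation of 2-5A-dependent ribonuclease (Homo sapiens), read by FRET; a higher number here means that more compound is needed for the effect, a lower number that less compound is needed. Compound 1 gives 49000 nM in this assay, and compound 2 gives 49000 nM. The two values are level at the digits shown, so compound 2 stands together with compound 1 and no difference between them lies outside the scatter; nothing here separates the two cores.

Compound 3 `CCOC(=O)C1=C(Nc2ccccc2)S/C(=C\c2cccc(O)c2)C1=O` has not yet been measured in this assay. It differs from compound 2 in one place: hydrogen in place of chloro on an aromatic carbon. For the measured compounds named here, no pair of measured compounds shows this change, so its effect is not known from the data. Given that compound 2 sits at 49000 nM, the step from compound 2 to compound 3 is expected to be small, at most a modest rise, and likely within the scatter a 1.2-fold higher number from compound 2 to compound 3 (0.09 log units; within the scatter). Compound 3 is therefore expected to give about 60000 nM in this assay, within a range from 25000 nM to 150000 nM.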

Compound 3, half-maximal effective concentration: 26000 nM
The estimate for compound 3 lay 2.3-fold (0.36 log units) above the measured number, within the range that was stated.
By their numbers in this assay, from the lowest: compounds 3, 1 and 2 (each within the scatter of the next).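

Going from 4-chlorophenyl to phenyl gives a 1.9-fold lower number from compound 2 to compound 3 (0.28 log units; within the scatter) in this assay, so this step stays within the scatter. The chloro on this aromatic carbon is therefore not required for compound 3 to give a reading in this assay, and the unsubstituted phenyl serves as a measured reference point for this position. Nothing available explains the size of this step or bears on how the chloro acts here.

The compounds shown cover only chloro and hydrogen at this place, so it remains open whether a methoxy group, an amine or a carboxylic acid there would move the number beyond the scatter. Also open, from the compounds shown here alone, is how a carboxylic acid or an amide in place of the ethyl ester would read with the phenyl kept.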